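The source may hold more compounds than are shown below. What is called first, only, known or untested is meant among the compounds shown, and "the series" means these compounds.

Measured so far:
compound 1 `FC(F)(F)c1ccc(CSc2nc(N3CCCCC3)c3ccccc3n2)cc1` — 18600 nM
compound 2 `COc1ccccc1Nc1nc(SCc2ccc(C(F)(F)F)cc2)nc2ccccc12` — > 50000 nM (assay limit)
compound 3 `O=[N+]([O-])c1ccc(Nc2nc(SCc3ccc(C(F)(F)F)cc3)nc3ccccc23)cc1` — 8170 nM

In a functional assay on MGC-803 cells (Homo sapiens) for cytotoxicity, read by MTT assay, with a stated time of 72 h (a lower number here means a stronger inhibitor, a higher number a weaker inhibitor), compound 1 gives 18600 nM, the highest of the two numbers shown, with compound 3 giving 8170 nM. Compound 2 reaches only a limit of this assay, > 50000 nM (the limit of > 50000 nM in this assay, at which 1 of the 3 values shown sits). Compound 4 `Cc1ccc(Nc2nc(SCc3ccc(C(F)(F)F)cc3)nc3ccccc23)cc1` is not yet measured; it differs from compound 1 as (4-methylphenyl)amino in place of piperidin-1-yl on an aromatic carbon. Going by the values given here, two measured steps bear on this change: an at least 2.6-fold higher number from compound 1 to compound 2 (0.42 log units; beyond the scatter) and a 2.3-fold lower number from compound 1 to compound 3 (0.36 log units; beyond the scatter), so replacing piperidin-1-yl by an arylamino group has moved the number both ways, and an at least 6.1-fold lower number from compound 2 to compound 3 (0.78 log units; beyond the scatter) shows how much the aryl group matters. With (4-methylphenyl)amino a modest step either way seems possible, so a number near compound 1 is expected. Compound 4 is estimated at 15000 nM, range 5000 nM to 50000 nM, an expected 1.2-fold lower number from compound 1 to compound 4 (0.09 log units; within the scatter).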

Compound 4, half-maximal inhibitory concentration: 36100 nM
For compound 4 the middle estimate is 2.4-fold (0.38 log units) below the measured one; the range from low to high includes it.
By their numbers in this assay, from the lowest: compound 3; then compounds 1 and 4 (each within the scatter of the next). At a limit, above all of these: compound 2.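

At this position, on the aromatic carbon next to the ring nitrogen, (4-methylphenyl)amino does not separate from piperidin-1-yl: a 1.9-fold higher number from compound 1 to compound 4 (0.29 log units; within the scatter). Among the arylamino compounds the group on the aryl ring matters more, as methyl in place of nitro gives a 4.4-fold higher number from compound 3 to compound 4 (0.65 log units; beyond the scatter). 4-Methylphenyl in place of 2-methoxyphenyl gives an at least 1.3-fold lower number from compound 2 to compound 4 (0.14 log units; that floor lies within the scatter), which is only a floor set by a limit: the limit of > 50000 nM in this assay, at which 1 of the 4 values shown sits.

Still open, on these data alone, is whether the lower number of compound 3 is specific to nitro. A nitrile, a carboxylic acid or an amine on the same aryl ring would test this.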